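Three amides and a cyclopentyl question

This account rests on a few compounds, and the source may have more. Where it says the series, first, only, none or still open, it means among the compounds named here.

compound 1 `CCC1C(=O)N(C)c2cnc(-n3ccc4cc(C(=O)NC(C)C)ccc43)nc2N1c1ccn(C)n1` gives 8910 nM
compound 2 `CCCNC(=O)c1ccc2c(ccn2-c2ncc3c(n2)N(c2ccn(C)n2)C(CC)C(=O)N3C)c1` gives 8270 nM
compound 3 `CCC1C(=O)N(C)c2cnc(-n3ccc4cc(C(=O)NCC(C)C)ccc43)nc2N1c1ccn(C)n1` gives 5600 nM

All three values come from a functional assay on K562 cells (Homo sapiens) for antiproliferative activity, read by CCK-8 assay, with a stated time of 72 h (a higher number here means a weaker inhibitor of growth, a lower number a stronger inhibitor of growth), and lie close together. Compound 3 gives 5600 nM and stays within the scatter of the other two, as a 1.6-fold lower number from compound 1 to compound 3 (0.20 log units; within the scatter) and a 1.5-fold lower number from compound 2 to compound 3 (0.17 log units; within the scatter) show. The next change is cyclopentyl in place of isobutyl on an amide-type nitrogen, which leads to compound 4 `CCC1C(=O)N(C)c2cnc(-n3ccc4cc(C(=O)NC5CCCC5)ccc43)nc2N1c1ccn(C)n1` and amounts to cyclopentyl in place of isobutyl on an amide-type nitrogen in counted terms. Going by the values given here, the steps that bear on it are the other changes on that same nitrogen: the two just given, and a 1.1-fold lower number from compound 1 to compound 2 (0.03 log units; within the scatter) for propyl in place of isopropyl. None of them leaves the scatter. Among the compounds with values here, no measured compound carries a ring on that nitrogen, so the data offer no direct precedent. No step beyond the scatter is expected, and the estimated change of a 1.2-fold higher number from compound 3 to compound 4 (0.06 log units; within the scatter) stays small on that basis. Compound 4 is expected at 6500 nM within an estimated range of 2800 nM to 14000 nM in this read-out.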

Compound 4, concentration for 50% growth inhibition: 31300 nM
Compound 4: the middle estimate sits 4.8-fold (0.68 log units) below what was measured; the whole stated range lies below it.
By their numbers in this assay, from the lowest: compounds 3, 2 and 1 (each within the scatter of the next); then compound 4.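

Going by these compounds alone, on the amide-type nitrogen, propyl, isopropyl and isobutyl had left the numbers in this assay within the scatter of one another, and cyclopentyl is the first change at this position to go beyond it. Set against each of the three open-chain amides, it gives the same direction of change (a 5.6-fold higher number from compound 3 to compound 4 (0.75 log units; beyond the scatter); a 3.8-fold higher number from compound 2 to compound 4 (0.58 log units; beyond the scatter); a 3.5-fold higher number from compound 1 to compound 4 (0.55 log units; beyond the scatter)), so among these four compounds the only one with a ring on that nitrogen, compound 4, is the weakest inhibitor of growth. No measurement at hand accounts for this step.

The compounds shown leave open whether the ring itself or the fifth carbon goes with this change. Cyclopropyl, cyclohexyl or a longer chain such as pentyl on the same nitrogen would begin to separate the two.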